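Replacing pyrazinyl with methylpyridinyl: expected rat exposure

The source may report more compounds than this note shows. Statements on the series, on what has been measured and on what is new or still open speak of the compounds shown alone.

Measured compounds:
compound 2 `Cc1cn2c(-c3cn[nH]c3)cnc2c(Nc2cc(Cc3nccs3)ns2)n1`: 1540 ng.h/mL
compound 3 `Cc1cn2c(-c3cn[nH]c3)cnc2c(Nc2cc(Cc3cnccn3)ns2)n1`: 58.4 ng.h/mL

In an ADME assay on the whole organism for pharmacokinetics, with Rattus norvegicus as the target, with a stated time of 6 h, at a dose of 10 mg/kg by the oral route (on this read-out higher numbers stand for higher exposure at the dose given and lower numbers for lower exposure), compound 1 `Cc1cn2c(-c3cn[nH]c3)cnc2c(Nc2cc(Cn3cccc(C)c3=O)ns2)n1` gives "not determined" (no result reported), so no number is reported for it. On the numbers shown, compound 3 stands lowest of the two; its nearest neighbour is compound 2, and the single measured step, a 26-fold lower number from compound 2 to compound 3 (1.42 log units; beyond the scatter), is large and beyond the scatter. Compound 4 `Cc1ccc(Cc2cc(Nc3nc(C)cn4c(-c5cn[nH]c5)cnc34)sn2)nc1` differs from compound 3 by 5-methylpyridin-2-yl in place of pyrazin-2-yl on a saturated chain carbon bound to an aromatic carbon. This exchange of one six-membered aromatic ring for another at the same position is not the same change as the measured step, so that step bears on it only by showing that the group on this saturated chain carbon can shift exposure widely. Compound 4 is therefore expected to move upward, a 6.8-fold higher number from compound 3 to compound 4 (0.84 log units; beyond the scatter), with an estimated 400 ng.h/mL in this assay, in a range from 60 ng.h/mL to 2500 ng.h/mL.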

Compound 4, area under the concentration-time curve: 1370 ng.h/mL
Compound 4: middle estimate off by 3.4-fold (0.53 log units), on the low side; the range from low to high includes it.
By their numbers in this assay, from the lowest: compound 3; then compounds 4 and 2 (each within the scatter of the next).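

In this assay, the low exposure of compound 3 does not hold for every six-membered aromatic ring at this place, as 5-methylpyridin-2-yl on the saturated chain carbon gives a large step (a 23-fold higher number from compound 3 to compound 4 (1.37 log units; beyond the scatter)). The 5-methylpyridin-2-yl and 1,3-thiazol-2-yl groups lie within the scatter of each other (a 1.1-fold lower number from compound 2 to compound 4 (0.05 log units; within the scatter)), which leaves compound 3 alone at the low end. Nothing available explains the large step.

The change swaps a ring nitrogen for carbon and adds a methyl together, and the compounds shown do not separate these two parts. Going by these compounds, an unsubstituted pyridin-2-yl would separate them, and how an amine on this ring would fare also stays open.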